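Replacing a trifluoromethylphenyl arm with a dimethyloxazole

The source may report more compounds than this note shows. Statements on the series, on what has been measured and on what is new or still open speak of the compounds shown alone.

Measured so far:
compound 1 `O=C(O)CS(=O)(=O)c1ccc(OCc2cccc(-c3ccccc3)c2)cc1` gives 288 nM
compound 2 `O=C(O)CS(=O)(=O)c1ccc(OCc2cccc(-c3ccccc3C(F)(F)F)c2)cc1` gives 52.5 nM

Both values come from a functional assay on CHO cells for agonist activity at Free fatty acid receptor 1 (Homo sapiens), read by FLIPR and calcium flux; a higher number here means that more compound is needed for the effect, a lower number that less compound is needed. Compound 2 stands at the lowest of the two numbers; its nearest neighbour is compound 1, and the step from one to the other is a 5.5-fold lower number from compound 1 to compound 2 (0.74 log units; beyond the scatter), which came from trifluoromethyl in place of hydrogen on an aromatic carbon.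

The next compound, compound 3 `Cc1noc(C)c1-c1cccc(COc2ccc(S(=O)(=O)CC(=O)O)cc2)c1`, has not yet been measured in this assay. It differs from compound 2 in one place: 3,5-dimethyl-1,2-oxazol-4-yl in place of 2-(trifluoromethyl)phenyl on an aromatic carbon. The change sits meta to a large group on the shared core.

Among the measured compounds shown here, only one measured step bears on this change, and only loosely: the step from compound 1 to compound 2 shows that what is attached at this position matters, but it does not show what a five-membered ring with two hetero atoms does there in place of a six-membered ring of carbon only. The expectation therefore leans on the neighbouring values without a direct precedent. For compound 3 the expected step is a 2.1-fold higher number from compound 2 to compound 3 (0.32 log units; beyond the scatter), a modest rise in the number that stays within the range spanned by the two measured compounds. The estimate for compound 3 is 110 nM, with a likely range from 30 nM to 400 nM.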

Compound 3, half-maximal effective concentration: 269 nM
The estimate for compound 3 lay 2.4-fold (0.39 log units) below the measured number, within the range that was stated.
By their numbers in this assay, from the lowest: compound 2; then compounds 3 and 1 (each within the scatter of the next).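

In this assay, 3,5-dimethyl-1,2-oxazol-4-yl in place of 2-(trifluoromethyl)phenyl gives a 5.1-fold higher number from compound 2 to compound 3 (0.71 log units; beyond the scatter) on the same core, so this five-membered ring does not keep the advantage that the trifluoromethylphenyl arm holds at this position. Compared with the plain phenyl arm, the same ring gives a 1.1-fold lower number from compound 1 to compound 3 (0.03 log units; within the scatter) and the two cannot be told apart, which shows that a five-membered aromatic ring with 2 hetero atoms and 2 hydrogen-bond acceptors can stand here in place of a six-membered ring of carbon only without a measurable change in this read-out. Among the three arms compared, only the trifluoromethylphenyl one stands apart, and nothing available explains why this arm differs from the other two.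

The compounds shown leave open what the two methyl groups on the 1,2-oxazole ring contribute, as every value here for that ring comes with both of them in place. Among the compounds shown here, they also leave open whether a chlorine atom or a methoxy group on the phenyl ring, in place of trifluoromethyl, would bring the number close to the one that compound 2 gives, 52.5 nM in this assay.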